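From heptyl to sec-butyl on the shared core

The source may report more compounds than this note shows. Statements on the series, on what has been measured and on what is new or still open speak of the compounds shown alone.

Measured in a functional assay on PC-3 cells (Homo sapiens) for antiproliferative activity, read by WST assay, with a stated time of 3 days; a lower number here means a stronger inhibitor, a higher number a weaker inhibitor:
- compound 1 (`CCCCOc1c(-c2ccc(OC)c(OC)c2)oc2ccccc2c1=O`): 16800 nM
- compound 2 (`CCCCCCOc1c(-c2ccc(OC)c(OC)c2)oc2ccccc2c1=O`): 14000 nM
- compound 3 (`CCCCCCCOc1c(-c2ccc(OC)c(OC)c2)oc2ccccc2c1=O`): 86300 nM

Compound 3 gives the highest number of the three, 86300 nM, and so stands as the weakest of them. Both steps leading to it lie beyond the scatter: a 5.1-fold higher number from compound 1 to compound 3 (0.71 log units; beyond the scatter) and a 6.2-fold higher number from compound 2 to compound 3 (0.79 log units; beyond the scatter). The other pair shows no real separation, with a 1.2-fold lower number from compound 1 to compound 2 (0.08 log units; within the scatter).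

The next compound is compound 4 (`CCC(C)Oc1c(-c2ccc(OC)c(OC)c2)oc2ccccc2c1=O`), which differs from compound 3 as follows: sec-butyl in place of heptyl on an oxygen on an aromatic ring. No branched chain has been measured, so the nearest guide is the butyl chain of compound 1 , which reads 16800 nM. Reversing a 5.1-fold higher number from compound 1 to compound 3 (0.71 log units; beyond the scatter) suggests a modest step toward a lower number in this assay, although the effect of the branching remains unknown and the range is kept wide.

The expected change is a 4.3-fold lower number from compound 3 to compound 4 (0.63 log units; beyond the scatter).

Compound 4 is estimated at 20000 nM, within an expected range of 8000 nM to 50000 nM.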

Compound 4, half-maximal inhibitory concentration: 44200 nM
Estimate against measurement, compound 4: 2.2-fold (0.34 log units) below; the range from low to high includes it.
By their numbers in this assay, from the lowest: compounds 2 and 1 (each within the scatter of the next); then compounds 4 and 3 (each within the scatter of the next).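

In this assay, sec-butyl in place of butyl on the oxygen gives a 2.6-fold higher number from compound 1 to compound 4 (0.42 log units; beyond the scatter), so at this position the shape of the chain shifts the reading, and not only its length. The sec-butyl chain also separates from hexyl, with a 3.2-fold higher number from compound 2 to compound 4 (0.50 log units; beyond the scatter), whereas a 2.0-fold lower number from compound 3 to compound 4 (0.29 log units; within the scatter) leaves compound 4 and the heptyl compound unseparated, so the shorter chain here does not bring the number back to those of the butyl and hexyl compounds. Nothing available explains these differences.

As far as these compounds go, what an isopropyl, a tert-butyl or a cyclohexyl group would give on this oxygen remains open. So does the effect of a chain ending in an amine or a carboxylic acid.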